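The source may hold more compounds than are shown below. What is called first, only, known or untested is meant among the compounds shown, and "the series" means these compounds.

Working notes on the series. Within the data shown here, in a functional assay on the whole organism for inhibition, with Echinochloa esculenta as the target (a lower number here means a stronger inhibitor, a higher number a weaker inhibitor), compound 2 `S=c1s/c(=N\c2ccc(Br)cc2)n2n1CCCC2` gives 245 nM, the middle of the three numbers so far. Compound 3 `S=c1n(-c2ccc(OCc3ccc(Cl)cc3)cc2)c(=S)n2n1CCCC2` sits higher at 871 nM, and compound 1 `CC(C)Oc1cc(-n2c(=S)n3n(c2=S)CCCC3)c(F)cc1Cl` sits lower at 12.3 nM. Both gaps from compound 2 lie beyond the scatter, with the gap to compound 1 the wider.

The next compound to be tested is compound 4 `S=c1s/c(=N\c2ccccc2)n2n1CCCC2`, which has hydrogen in place of bromo on an aromatic carbon of compound 2: hydrogen in place of bromo on an aromatic carbon. Among the measured compounds shown here, no two measured compounds differ in only one place, so the series offers no direct precedent for this change, and the expectation below is loosely held. A moderate move towards a weaker inhibitor is expected, with the estimated change being a 2.0-fold higher number from compound 2 to compound 4 (0.31 log units; beyond the scatter). A result within the scatter of compound 2 would not be surprising. For compound 4 the estimated value in this assay is 500 nM, with an expected range of 150 nM to 1700 nM.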

Compound 4, half-maximal inhibitory concentration: 15100 nM
Estimate against measurement, compound 4: 30-fold (1.48 log units) below; the whole stated range lies below it.
By their numbers in this assay, from the lowest: compound 1; then compound 2; then compound 3; then compound 4.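

Among these compounds, this is the first step that changes one place only, and in this assay it is large: hydrogen in place of bromo on an aromatic carbon, para to a large group, gives a 62-fold higher number from compound 2 to compound 4 (1.79 log units; beyond the scatter). Among the compounds shown here, the inhibition seen for compound 2 therefore depends heavily on having bromo rather than hydrogen at this position, which the earlier compounds, differing in several places at once, could not show. Nothing at hand bears on why the step is this large.

As far as these compounds go, whether bromo is specifically required here or another group at the same position, such as methoxy or an amine, would serve as well remains open. Also open, from the compounds shown here alone, is whether this position matters as much on the core of compound 1, where the aromatic ring carries different groups.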